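Aryl sulfonamide piperidines: cytotoxicity notes toward compound 3

A few compounds are considered here, and "the series" means these few. Any claim that something is new, unique, unknown or untested is made for them only; others in the source may bear on it.

Measured so far:
compound 1 `CC1CCN(C2CCN(S(=O)(=O)c3cccnc3Cl)CC2)CC1` — > 10000 nM
compound 2 `Cc1cc(C)c(S(=O)(=O)N2CCC(N3CCN(C)CC3)CC2)c(C)c1` — > 5000 nM

In an ADME assay on HCT-116 cells (Homo sapiens) for cytotoxicity, read by CellTiter-Glo, with a stated time of 72 h (a lower number here means a stronger inhibitor, a higher number a weaker inhibitor), compound 1 gives > 10000 nM, which is a limit of the assay rather than a number. Compound 2 in this assay gives > 5000 nM, likewise only a limit. Compound 1 therefore stands at the limit of > 10000 nM in this assay, at which 1 of the 2 values shown sits, with no measured number to place it against compound 2; the other value sits at the limit of > 5000 nM in this assay, at which 1 of the 2 values shown sits. Going by the values given here, no pair of measured compounds differing in one place exists, so no measured step is available.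

Compound 3 `COc1cccc(S(=O)(=O)N2CCC(N3CCC(C)CC3)CC2)c1` differs from compound 1 in one place: 3-methoxyphenyl in place of 2-chloropyridin-3-yl on a sulfonyl sulfur. With both measured compounds at limits, the step in this assay is expected to be none beyond the scatter, and compound 3 is expected to remain at a limit. The estimate for compound 3 in this assay is 20000 nM, ranging from 5000 nM to 100000 nM. The expected step is a step that the limit leaves unreadable from compound 1 to compound 3, essentially flat.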

Compound 3, half-maximal inhibitory concentration: > 5000 nM
Compound 3 was reported as a limit; the forecaster's own chance of this, stated with the estimate: 80%; the middle value is on the limit's open side.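

Compound 1 and compound 3 are both reported only as limits in this assay, so the step between them cannot be read. The compounds shown leave open where any of them would reach half-maximal inhibition in this assay, and whether changing the sulfonyl aryl group shifts that value.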